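The source may report more compounds than this note shows. Statements on the series, on what has been measured and on what is new or still open speak of the compounds shown alone.

Three compounds share one core and differ only in the ring attached to the saturated ring carbon. Compound 1 `COc1cc(/C=C/C(=O)C2=C(/C=C/c3ccc(O)c(OC)c3)NC(=O)NC2c2ccccc2)ccc1O` carries a bare phenyl there and in a functional assay, with a stated time of 20 min, tested at 20 uM (a lower number here means a weaker effect, a higher number a stronger effect of the compound at the concentration tested), compound 1 gives 38.2%. Compound 2 `COc1cc(/C=C/C(=O)C2=C(/C=C/c3ccc(O)c(OC)c3)NC(=O)NC2c2ccccc2O)ccc1O` gives 81%, and compound 3 `COc1cc(/C=C/C(=O)C2=C(/C=C/c3ccc(O)c(OC)c3)NC(=O)NC2c2ccc(O)cc2)ccc1O` gives 84.6%. Adding a hydroxy on that ring made a large difference: a number 42.8 percentage points higher from compound 1 to compound 2 (beyond the scatter) and a number 46.4 percentage points higher from compound 1 to compound 3 (beyond the scatter). Where the hydroxy sits mattered little, since a number 3.6 percentage points higher from compound 2 to compound 3 (within the scatter). Compound 3 therefore holds the highest of the three numbers, with compound 2 within the scatter of it and compound 1 far beneath.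

Compound 4 `COc1cc(/C=C/C(=O)C2=C(/C=C/c3ccc(O)c(OC)c3)NC(=O)NC2c2ccc(N(C)C)cc2)ccc1O` takes the next step from compound 3: dimethylamino in place of hydroxy on an aromatic carbon. Among the compounds with values here, no measured step shows dimethylamino in this place. From the compounds shown here alone, the steps from compound 1 show that removing the hydroxy alone cost much; whether dimethylamino gives any of that back is unknown, so a drop of uncertain size is expected, a number 29.6 percentage points lower from compound 3 to compound 4 (beyond the scatter). Compound 4 is estimated at 55%, between 30% and 82%.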

Compound 4, a percentage reported as activity, at one concentration (the size of the read-out at that concentration, not a potency): 48%
Beside the measured number, compound 4's estimate is 7 percentage points above it; the measured number falls inside the stated range.
By their numbers in this assay, from the lowest: compounds 1 and 4 (each within the scatter of the next); then compounds 2 and 3 (each within the scatter of the next).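

In this assay dimethylamino does not match hydroxy on this ring, with a number 36.6 percentage points lower from compound 3 to compound 4 (beyond the scatter) and with a number 33 percentage points lower from compound 2 to compound 4 (beyond the scatter) as well. Against the bare phenyl, dimethylamino gives a number 9.8 percentage points higher from compound 1 to compound 4 (within the scatter) and so leaves compound 4 level with compound 1, which shows that merely putting a group on this ring is not enough: among these four compounds, the large gain appears only with hydroxy. Hydroxy counts one hydrogen-bond donor and dimethylamino none, but no measurement here ties the drop to that count or to any other property of the two groups.

Still open, from the compounds shown here alone, is how a plain amino group or a methoxy at this place would compare with hydroxy and dimethylamino. A carboxylic acid at the same place is equally unknown territory.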